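The source may report more compounds than this note shows. Statements on the series, on what has been measured and on what is new or still open speak of the compounds shown alone.

Measured in a functional assay on MNK45 cells (Homo sapiens) for inhibition, read by MTT assay, with a stated time of 48 h; a lower number here means a stronger inhibitor, a higher number a weaker inhibitor: compound 1 `Cc1ccc(NC(=S)NC(=O)c2ccc(OCc3ccccc3)cc2)cc1-c1nc2ccccc2[nH]1` gives 57800 nM, compound 2 `Cc1ccc(NC(=S)NC(=O)c2ccc(OCc3cccc(C(F)(F)F)c3)cc2)cc1-c1nc2ccccc2[nH]1` gives 6050 nM, and compound 3 `Cc1ccc(NC(=S)NC(=O)c2ccc(OCc3cccc(F)c3)cc2)cc1-c1nc2ccccc2[nH]1` gives 86800 nM.

Compound 2 gives the lowest number of the three, with its steps to both other compounds beyond the scatter, so it is the strongest inhibitor among them. The step now followed is 3,4-dichlorophenyl in place of 3-(trifluoromethyl)phenyl on a saturated chain carbon bound to an oxygen on an aromatic ring, which gives compound 4 `Cc1ccc(NC(=S)NC(=O)c2ccc(OCc3ccc(Cl)c(Cl)c3)cc2)cc1-c1nc2ccccc2[nH]1`. Among the measured compounds shown here, two measured steps bear on it: a 9.6-fold lower number from compound 1 to compound 2 (0.98 log units; beyond the scatter) and a 14-fold higher number from compound 2 to compound 3 (1.16 log units; beyond the scatter). For the measured compounds named here, both show that changing the group at this place can move the number well beyond the scatter, but no measured step tests two chlorines there, so the direction remains open. In this assay compound 4 is expected to give about 5000 nM, in the range 1500 nM to 20000 nM. The expected step is a 1.2-fold lower number from compound 2 to compound 4 (0.08 log units; within the scatter), close to the scatter.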

Compound 4, half-maximal inhibitory concentration: 8410 nM
Compound 4: the middle estimate sits 1.7-fold (0.23 log units) below what was measured, within the range that was stated.
By their numbers in this assay, from the lowest: compounds 2 and 4 (each within the scatter of the next); then compounds 1 and 3 (each within the scatter of the next).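

Among the compounds shown here, the 3,4-dichlorophenyl group does about the same as 3-(trifluoromethyl)phenyl at this place (a 1.4-fold higher number from compound 2 to compound 4 (0.14 log units; within the scatter)), so trifluoromethyl is not the only group that reaches the low end of this series. Both 3-fluorophenyl (a 10-fold lower number from compound 3 to compound 4 (1.01 log units; beyond the scatter)) and plain phenyl (a 6.9-fold lower number from compound 1 to compound 4 (0.84 log units; beyond the scatter)) give clearly higher numbers than 3,4-dichlorophenyl. Nothing available explains why these groups differ. Still open, as far as these compounds go, is how a phenyl carrying a single chlorine, an amine or a carboxylic acid would compare at this place.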